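The compounds below may be only part of what the source reports. "The series", "measured", "known", "first", "only" and "open" are said of these compounds alone.

Measured compounds in a functional assay on Ehrlich cells (Mus musculus) for cytotoxicity, read by trypan blue exclusion, with a stated time of 2 h, tested at 10 ug/mL; on this read-out lower numbers stand for a weaker effect and higher numbers for a stronger effect at the one concentration tested:

compound 1, `Cc1ccc(C(=O)NC2=C(C#N)C(c3ccc(Cl)cc3Cl)C3=C(CCCC3=O)N2c2ccc(S(N)(=O)=O)cc2)cc1`, gives 20%
compound 2, `N#CC1=C(NC(=O)/C=C/c2ccccc2)N(c2ccc(S(N)(=O)=O)cc2)C2=C(C(=O)CCC2)C1c1ccc(Cl)cc1Cl`, gives 30%

Among the measured compounds shown here, compound 2 has the higher of the two numbers, with compound 1 nearest: the single measured step, a number 10 percentage points higher from compound 1 to compound 2 (within the scatter), lies within the scatter, so the two compounds cannot be told apart on this read-out. For the measured compounds named here, the only measured step exchanges the group on the carbonyl carbon of the amide, and it produced no change beyond the scatter.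

Compound 3, `CC(=O)CC(=O)NC1=C(C#N)C(c2ccc(Cl)cc2Cl)C2=C(CCCC2=O)N1c1ccc(S(N)(=O)=O)cc1`, is not yet measured. It differs from compound 2 at the same place: 2-oxopropyl in place of 2-phenylethenyl on a carbonyl carbon. The step from compound 1 to compound 2 bears on it only in that the same carbonyl carbon was varied there, and that variation gave a small number within the scatter. Going by the values given here, there is no measured step in which the group on that carbonyl carbon was shortened or a second carbonyl introduced, so nothing in the data points to a large move in either direction.

For compound 3 the expected step of a number 5 percentage points lower from compound 2 to compound 3 (within the scatter) is therefore one that stays within the scatter. Compound 3 is estimated at 25%, with a range from 10% to 40%.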

Compound 3, a percentage reported as activity, at one concentration (the size of the read-out at that concentration, not a potency): 40%
Compound 3: middle estimate off by 15 percentage points, on the low side, and the stated range covers the measured number.
By their numbers in this assay, from the lowest: compounds 1, 2 and 3 (each within the scatter of the next, the first and the last beyond it).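

Working note on the group on the carbonyl carbon of the amide: in this assay, 2-oxopropyl gives the first step at this place to clear the scatter, a number 20 percentage points higher from compound 1 to compound 3 (beyond the scatter), so this position can shift the read-out when 4-methylphenyl is exchanged. Against 2-phenylethenyl the same group gives a number 10 percentage points higher from compound 2 to compound 3 (within the scatter), which does not separate the two, so on this read-out a group with no ring and one hydrogen-bond acceptor matches a larger group with a six-membered aromatic ring, and the ring is not needed to reach the number seen for compound 3. Nothing available accounts for the step from 4-methylphenyl to 2-oxopropyl.

The exchange removes the aromatic ring and adds the oxygen of 2-oxopropyl in one move, so the step cannot be assigned to either difference alone. A plain propyl chain on the same carbonyl carbon would separate the two, and a carboxylic acid or an amine at the end of such a chain would show how far this position tolerates other ends.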